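The source may hold more compounds than are shown below. What is called first, only, known or untested is meant among the compounds shown, and "the series" means these compounds.

In a functional assay on T-24 cells (Homo sapiens) for antiproliferative activity, read by MTT assay, with a stated time of 48 h (on this read-out higher numbers stand for weaker inhibition and lower numbers for stronger inhibition), compound 1 `O=C(Nc1cccc(CNc2nccnc2Cl)c1)Nc1ccc(Cl)cc1Cl` gives 5740 nM and compound 2 `O=C(Nc1cccc(CNc2nccnc2Cl)c1)Nc1ccccc1F` gives 7450 nM on the same scale, with a measured step of a 1.3-fold higher number from compound 1 to compound 2 (0.11 log units; within the scatter) between them. Compound 3 `O=C(Nc1cccc(CNc2nccnc2Cl)c1)NC1CCCCC1` stands at > 40000 nM as a limit of the assay and not as a number. Compound 4 `O=C(Nc1cccc(CNc2nccnc2Cl)c1)Nc1ccccc1Cl` differs from compound 3 in one place, with 2-chlorophenyl in place of cyclohexyl on an amide-type nitrogen and the rest unchanged. Two measured steps bring in cyclohexyl on that same nitrogen, namely an at least 6.9-fold higher number from compound 1 to compound 3 (0.84 log units; beyond the scatter) and an at least 5.3-fold higher number from compound 2 to compound 3 (0.72 log units; beyond the scatter) in the opposite sense. Read backwards, they point to a lower number and stronger inhibition, so the expected step is an at least 6.1-fold lower number from compound 3 to compound 4 (0.78 log units; beyond the scatter) in this assay terms. For compound 4 the estimate is 6500 nM with an expected range from 3300 nM to 13000 nM.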

Compound 4, half-maximal inhibitory concentration: 6680 nM
Estimate against measurement, compound 4: 1.0-fold (0.01 log units) below; measured number inside the range.
By their numbers in this assay, from the lowest: compounds 1, 4 and 2 (each within the scatter of the next). At a limit, above all of these: compound 3.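

In this assay, 2-chlorophenyl in place of cyclohexyl on the amide-type nitrogen gives an at least 5.9-fold lower number from compound 3 to compound 4 (0.77 log units; beyond the scatter). Compound 3 stands at a limit of the assay, not at a number: the limit of > 40000 nM in this assay, at which 1 of the 4 values shown sits. Among the phenyl compounds, chloro in place of fluoro gives a 1.1-fold lower number from compound 2 to compound 4 (0.05 log units; within the scatter), and hydrogen in place of chloro gives a 1.2-fold higher number from compound 1 to compound 4 (0.07 log units; within the scatter), so neither of these swaps on the ring moves the read-out beyond the scatter. Still open, from the compounds shown here alone, is whether a methoxy or a carboxylic acid on that phenyl ring would give numbers at this same level. Also open, going by these compounds, is whether a benzyl group on the nitrogen would behave like the phenyl rings or like cyclohexyl.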